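A few compounds are considered here, and "the series" means these few. Any claim that something is new, unique, unknown or untested is made for them only; others in the source may bear on it.

Compounds measured so far:

Compound 1, `COc1cc2cc(Oc3ccc(NC(=O)Nc4ccccc4)cc3)c(C)nc2cc1OC` — 70.7%
Compound 2, `COc1cc2cc(Oc3ccc(NC(=O)Nc4ccc(C)cc4)cc3)c(C)nc2cc1OC` — 93%
Compound 3, `COc1cc2cc(Oc3ccc(NC(=O)Nc4ccc(C(F)(F)F)cc4)cc3)c(C)nc2cc1OC` — 72.2%

In a functional assay on SN12C cells (Homo sapiens) for inhibition, read by sulforhodamine B assay, with a stated time of 48 h, tested at 10 uM (on this read-out lower numbers stand for a stronger effect and higher numbers for a weaker effect at the one concentration tested), compound 3 stands second highest of the three numbers. Its nearest neighbour is compound 1, with a number 1.5 percentage points higher from compound 1 to compound 3 (within the scatter), a step within the scatter. Compound 2 lies furthest from it, with a number 20.8 percentage points lower from compound 2 to compound 3 (beyond the scatter), a step beyond the scatter. Compound 4, `COc1cc2cc(Oc3ccc(NC(=O)Nc4cccc(C(F)(F)F)c4)cc3)c(C)nc2cc1OC`, has not yet been measured in this assay. It differs from compound 3 by 3-(trifluoromethyl)phenyl in place of 4-(trifluoromethyl)phenyl on an amide-type nitrogen; the two compounds hold the same atoms, joined differently.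

Among the measured compounds shown here, none of the measured steps moves a trifluoromethyl group from one aromatic carbon to another. The steps that touch this group, a number 1.5 percentage points higher from compound 1 to compound 3 (within the scatter) and a number 20.8 percentage points lower from compound 2 to compound 3 (beyond the scatter), show that a trifluoromethyl group at the position used in compound 3 behaves much like hydrogen and differs from methyl only modestly. For the measured compounds named here, with no direct precedent, the step is expected to stay within the scatter, a number 0.2 percentage points lower from compound 3 to compound 4 (within the scatter). Compound 4 is therefore estimated at 72%, between 55% and 90%.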

Compound 4, a percentage reported as activity, at one concentration (the size of the read-out at that concentration, not a potency): 17.2%
Beside the measured number, compound 4's estimate is 54.8 percentage points above it, outside the stated range (below it).
By their numbers in this assay, from the lowest: compound 4; then compounds 1 and 3 (each within the scatter of the next); then compound 2.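

In this assay, the placement of the trifluoromethyl group matters, not just its presence: exchanging 4-(trifluoromethyl)phenyl for 3-(trifluoromethyl)phenyl on the amide-type nitrogen gives a number 55 percentage points lower from compound 3 to compound 4 (beyond the scatter) even though the atoms stay the same. Trifluoromethyl in place of hydrogen had looked nearly silent in compound 3, yet in its other placement the same exchange gives a number 53.5 percentage points lower from compound 1 to compound 4 (beyond the scatter) and thus has a large effect, while the exchange of 4-methylphenyl for 3-(trifluoromethyl)phenyl gives a number 75.8 percentage points lower from compound 2 to compound 4 (beyond the scatter) as the widest step in the set. No evidence is available to explain why the placement carries so much weight.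

From the compounds shown here alone, whether a nitrile, a methoxy group or an amine in place of the trifluoromethyl group of compound 4 would give a similar number remains open. So does whether a second such group on the same phenyl would add to the effect.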